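This account rests on a few compounds, and the source may have more. Where it says the series, first, only, none or still open, it means among the compounds named here.

Measured in a functional assay on KB cells (Homo sapiens) for cytotoxicity; on this read-out lower numbers stand for stronger inhibition and higher numbers for weaker inhibition:
- Compound 1 `Cc1ccc(Cn2cc(C#N)c3c(N)ncnc32)cc1`: > 100000 nM
- Compound 2 `Cc1ccc(Cn2cc(C(=N)S)c3c(N)ncnc32)cc1`: 65000 nM

Among the measured compounds shown here, compound 2, at 65000 nM, holds the only actual number so far. Compound 1 reads > 100000 nM, which is a limit of the assay and not a number.

Compound 3 `Cn1cc(C(=N)S)c2c(N)ncnc21` differs from compound 2 by hydrogen in place of 4-methylphenyl on a saturated chain carbon bound to an aromatic nitrogen. For the measured compounds named here, the one measured step, an at least 1.5-fold lower number from compound 1 to compound 2 (0.18 log units; that floor lies within the scatter), changed a different place, so it offers only weak guidance here. It shows how little separates the values in this assay, so no shift beyond the scatter is expected, and compound 3 may again reach (the limit of > 100000 nM in this assay, at which 1 of the 2 values shown sits). The expected step is a 1.2-fold higher number from compound 2 to compound 3 (0.09 log units; within the scatter). The estimate for compound 3 is 80000 nM, with an expected range of 30000 nM to 200000 nM.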

Compound 3, half-maximal inhibitory concentration: 15000 nM
Compound 3: middle estimate off by 5.3-fold (0.73 log units), on the high side, outside the stated range (below it).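

In this assay replacing 4-methylphenyl with hydrogen on the saturated chain carbon bound to an aromatic nitrogen brings a 4.3-fold lower number from compound 2 to compound 3 (0.64 log units; beyond the scatter) and shows that this position does influence the read-out. This is the first step shown that lies beyond the scatter, and the measurable cytotoxicity of compound 3 shows that the 4-methylphenyl ring is not required for it. Nothing at hand explains why the number falls.

The compounds shown leave open how an amine, a carboxylic acid or a longer chain would behave at this place.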